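Notes on the aryl replacement leading to compound 3

A few compounds are considered here, and "the series" means these few. Any claim that something is new, unique, unknown or untested is made for them only; others in the source may bear on it.

compound 1 `COc1cc(C(=O)c2sc3ccccc3c2-c2ccc(F)cc2)cc(OC)c1OC`: 3000 nM
compound 2 `COc1cc(C(=O)c2sc3ccccc3c2-c2ccc(SC)cc2)cc(OC)c1OC`: 3500 nM

Within the data shown here, in a functional assay on HeLa cells (Homo sapiens) for antiproliferative activity, read by MTT assay, with a stated time of 72 h (on this read-out lower numbers stand for stronger inhibition and higher numbers for weaker inhibition), compound 1 gives 3000 nM, the lowest of the two numbers so far, though a 1.2-fold higher number from compound 1 to compound 2 (0.07 log units; within the scatter) is within the scatter, so compound 1 and compound 2 cannot be ranked against each other. In this assay compound 2 gives 3500 nM.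

Compound 3 `COc1ccccc1-c1c(C(=O)c2cc(OC)c(OC)c(OC)c2)sc2ccccc12` has not yet been measured. It differs from compound 1 by 2-methoxyphenyl in place of 4-fluorophenyl on an aromatic carbon. Among the measured compounds shown here, the only measured step, a 1.2-fold higher number from compound 1 to compound 2 (0.07 log units; within the scatter), swaps one group for another on the same ring and moves the number by less than the scatter. The change to compound 3 brings in a different group, named as above, so that step is only a loose guide; nothing measured speaks for a large shift in either direction.

The step of a 1.3-fold higher number from compound 1 to compound 3 (0.12 log units; within the scatter) is therefore expected to be small, most likely a somewhat higher number, within or close to the scatter. Compound 3 is estimated to give about 4000 nM in this assay, with a range from 1500 nM to 12000 nM.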

Compound 3, half-maximal inhibitory concentration: 5000 nM
Compound 3: the middle estimate sits 1.3-fold (0.10 log units) below what was measured; measured number inside the range.
By their numbers in this assay, from the lowest: compounds 1, 2 and 3 (each within the scatter of the next).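

Among these compounds, on the aromatic carbon two ring bonds from the ring sulfur, the earlier compounds varied only the group on a 4-substituted phenyl, whereas compound 3 replaces that aryl group with 2-methoxyphenyl, so both the substituent and its place on the phenyl ring differ. In this assay this gives a 1.7-fold higher number from compound 1 to compound 3 (0.22 log units; within the scatter) and a 1.4-fold higher number from compound 2 to compound 3 (0.15 log units; within the scatter), so compound 3 cannot be ranked against either compound, and 4-fluorophenyl, 4-(methylsulfanyl)phenyl and 2-methoxyphenyl are not told apart at this place on the shared core. No measurement at hand bears on why these numbers lie so close.

Because the substituent and its place on the phenyl ring differ together in compound 3, the contribution of each remains unresolved, and a direct comparison with 4-methoxyphenyl would be needed to separate them. Also open, from the compounds shown here alone, is whether a phenyl ring carrying an aminomethyl group or a carboxylic acid, or a longer chain such as butoxy, would move the number beyond the scatter in this assay.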